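The source may report more compounds than this note shows. Statements on the series, on what has been measured and on what is new or still open speak of the compounds shown alone.

The measured compounds:
compound 1, `O=C(N/N=C/c1cccc(Cl)c1)c1cccnc1Nc1cccc(C(F)(F)F)c1` — 55.2%
compound 2, `COc1ccc(/C=N/NC(=O)c2cccnc2Nc2cccc(C(F)(F)F)c2)cc1OC` — 44%

In a functional assay on the whole organism (strain Wistar) for inhibition, with Rattus norvegicus as the target, read by paw edema, with a stated time of 3 h, at a dose of 10 mg/kg by the intraperitoneal route (on this read-out lower numbers stand for less inhibition and higher numbers for more inhibition at the one dose given (going by the name of the read-out)), compound 1 gives 55.2%, the highest of the two numbers, while compound 2 gives 44%. Among the compounds with values here, the one measured step at this position is a number 11.2 percentage points lower from compound 1 to compound 2 (beyond the scatter). Compound 3, `O=C(N/N=C/c1ccncc1)c1cccnc1Nc1cccc(C(F)(F)F)c1`, differs from compound 1 by pyridin-4-yl in place of 3-chlorophenyl on a carbon with a double bond to nitrogen. That single step bears on the change only loosely, since pyridin-4-yl at this place has not been measured. A modest downward step in this assay is therefore expected, with wide uncertainty. Compound 3 is expected to give 45%, within 30% to 60%. This expected change is a number 10.2 percentage points lower from compound 1 to compound 3 (beyond the scatter).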

Compound 3, a percentage reported as inhibition, in the whole organism at one dose (the size of the read-out at that dose, not a potency): 54.9%
Estimate against measurement, compound 3: 9.9 percentage points below; measured number inside the range.
By their numbers in this assay, from the lowest: compound 2; then compounds 3 and 1 (each within the scatter of the next).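

Pyridin-4-yl on the carbon with a double bond to nitrogen stays level with 3-chlorophenyl in this assay, with a number 0.3 percentage points lower from compound 1 to compound 3 (within the scatter). Against 3,4-dimethoxyphenyl it shows a number 10.9 percentage points higher from compound 2 to compound 3 (beyond the scatter), so the earlier fall is not common to every replacement of 3-chlorophenyl at this place. No evidence is available to account for these steps. The compounds shown leave open how a piperidine ring, or a phenyl ring carrying a carboxylic acid, would compare here. All these numbers come from one dose, so they do not give potency.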